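Adding a chloro to compound 2: what to expect

A few compounds are considered here, and "the series" means these few. Any claim that something is new, unique, unknown or untested is made for them only; others in the source may bear on it.

Values so far in a physicochemical assay for solubility, using the shake flask method, measured as kinetic solubility, with a stated time of 2 h, at pH 7.4; a lower number here means a less soluble compound, a higher number a more soluble compound (both are limits, not numbers)
- compound 1 `COc1ccc(NC(=O)c2cc(N(C)Cc3ccccc3)ncn2)cc1` reports < 5000 nM (a limit)
- compound 2 `CN(Cc1ccccc1)c1cc(C(=O)Nc2ccccc2)ncn1` reports < 5000 nM (a limit)

Compound 2 therefore has no exact place on the scale, and its entry of < 5000 nM is only a limit of the assay. Compound 3 `CN(Cc1ccccc1Cl)c1cc(C(=O)Nc2ccccc2)ncn1` keeps the same core and makes a single change, (chloro in place of hydrogen on an aromatic carbon), which turns benzyl to 2-chlorobenzyl. Among the compounds with values here, the one measured step, a step that the two limits leave unreadable from compound 1 to compound 2, has no size that can be carried over, so it gives no guide to size or direction. The data so far show (the limit of < 5000 nM in this assay, at which 2 of the 2 values shown sit), and compound 3 is accordingly expected to report that same limit in this assay, with no step beyond the usual scatter. Should a number appear, compound 3 is estimated at 2500 nM (expected range 800 nM to 5000 nM). The expected step is a step that the limit leaves unreadable from compound 2 to compound 3, which is an estimate only and awaits measurement.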

Compound 3, solubility: < 5000 nM
Compound 3: only a limit was reported; the forecaster's own chance of this, stated with the estimate: 90%; the middle value lies beyond the limit too.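

In this assay compound 3 gives < 5000 nM, which is a limit and not a number. Within the data shown here, compound 2 also has only a limit, so no step from compound 2 to compound 3 can be read. Where compound 1, compound 2 and compound 3 truly lie, and whether 2-chlorobenzyl differs from benzyl here, stays open, as all the values shown share one reading: the limit of < 5000 nM in this assay, at which 3 of the 3 values shown sit.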